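Tetrazole-series notes: extended nitrogen-bound chain, compound 1 to compound 4

A few compounds are considered here, and "the series" means these few. Any claim that something is new, unique, unknown or untested is made for them only; others in the source may bear on it.

Among the measured compounds shown here, compound 1 `CC(C)(N)C(=O)N[C@H](COCc1ccccc1)c1nnnn1CCCc1ccccc1` is the only member of this set with a number in an assay on isolated protein for displacement of a labelled ligand from growth hormone secretagogue receptor type 1 (Homo sapiens), with a stated time of 1 h; on this read-out lower numbers stand for stronger inhibition and higher numbers for weaker inhibition: compound 1 gives 200 nM there. Compound 2 `CC(C)(N)C(=O)N[C@H](COCc1ccccc1)c1nnn(C/C=C/c2ccccc2)n1` reaches only a limit of this assay, > 5000 nM. Compound 3 `CC(C)(N)C(=O)N[C@H](COCc1ccccc1)c1nnn(CC#N)n1` likewise gives a limit, > 5000 nM. For the measured compounds named here, the one single-point step with both ends measured, a step that the two limits leave unreadable from compound 2 to compound 3, cannot be read because both ends sit at the limit of > 5000 nM in this assay, at which 2 of the 3 values shown sit, so it says nothing about size or direction. Going by the values given here, no step is given between compound 1 and compound 2 or compound 3; their values show only that compound 1 yields a number where the others yield limits.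

Compound 4 `CC(C)(N)C(=O)N[C@H](COCc1ccccc1)c1nnnn1CCC(=O)NCCCc1ccccc1` differs from compound 1 by (3-phenylpropyl)carbamoyl in place of benzyl on a saturated chain carbon, two bonds along the chain from an aromatic nitrogen. Among the compounds with values here, no measured step touches this position, so the expectation rests on compound 1 alone. The aromatic ring is kept and the chain grows; the estimate for compound 4 is 400 nM, between 100 nM and 2000 nM, an expected step of a 2.0-fold higher number from compound 1 to compound 4 (0.30 log units; within the scatter) from compound 1.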

Compound 4, inhibition constant: 820 nM
Estimate against measurement, compound 4: 2.1-fold (0.31 log units) below; low and high end bracket the measured number.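

In this assay, among the compounds shown here, (3-phenylpropyl)carbamoyl in place of benzyl gives a 4.1-fold higher number from compound 1 to compound 4 (0.61 log units; beyond the scatter), the first readable step in this set and the first at this position. The position on a saturated chain carbon, two bonds along the chain from an aromatic nitrogen, therefore takes a larger group carrying a carbonyl and an amide hydrogen at a modest cost, and compound 4 still returns a number. Compound 2 and compound 3 remain at a limit of the assay, not a number: the limit of > 5000 nM in this assay, at which 2 of the 4 values shown sit.

This change brings in added length and the amide together, and the compounds shown do not separate the two. Also open, on these data alone, is how the position responds to an amine, a carboxylic acid or a longer chain without the terminal phenyl ring.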